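The source may report more compounds than this note shows. Statements on the series, on what has been measured and on what is new or still open speak of the compounds shown alone.

Compound 1 `Cc1ccc(OCC(=O)N(Cc2cccs2)c2cccnc2)cc1` is measured in an assay on HEK293 cells for agonist activity at transient receptor potential cation channel subfamily M member 8 (Homo sapiens), read by fluorescence and calcium flux, with a stated time of 15 min (on this read-out higher numbers stand for an effect only at larger amounts of compound and lower numbers for an effect already at smaller amounts), beside two others, compound 2 `CCN(Cc1cccnc1)C(=O)COc1ccc(C)cc1` and compound 3 `CCN(Cc1cccs1)C(=O)COc1ccc(C(C)C)cc1`. In this assay compound 1 gives 198 nM, compound 3 gives 397 nM, and compound 2 gives 15400 nM. Compound 1 holds the lowest of the three numbers; its value and that of compound 3 lie within the usual scatter of each other, while the value of compound 2 lies well beyond it. Compound 4 `Cc1ccc(OCC(=O)N(Cc2cccs2)c2c(C)n[nH]c2C)cc1` has not yet been measured. It differs from compound 1 in one place: 3,5-dimethyl-1H-pyrazol-4-yl in place of pyridin-3-yl on an amide-type nitrogen. Among the compounds with values here, no measured pair shows this change. The expected step from compound 1 to compound 4 a 2.5-fold higher number from compound 1 to compound 4 (0.40 log units; beyond the scatter) is a moderate move toward a higher number, with the direction left uncertain. Compound 4 is estimated to give about 500 nM in this assay, within a range of 120 nM to 2500 nM.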

Compound 4, half-maximal effective concentration: 0.3 nM
For compound 4 the middle estimate is 1700-fold (3.22 log units) above the measured one; the whole stated range lies above it.
By their numbers in this assay, from the lowest: compound 4; then compounds 1 and 3 (each within the scatter of the next); then compound 2.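

In this assay, within the data shown here, 3,5-dimethyl-1H-pyrazol-4-yl in place of pyridin-3-yl on the amide-type nitrogen gives a 660-fold lower number from compound 1 to compound 4 (2.82 log units; beyond the scatter), so the read-out proves highly sensitive to the group at this position, which no earlier pair had tested. The entering group counts one hydrogen-bond donor and the leaving group none, but nothing available accounts for the size of this step. The compounds shown leave open whether the result depends on the two methyl groups, which 1H-pyrazol-4-yl would address, or on the nitrogen-bound hydrogen, which 3,5-dimethylisoxazol-4-yl would address.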